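A branched secondary amine in place of a tertiary one

The source may hold more compounds than are shown below. What is called first, only, known or untested is meant among the compounds shown, and "the series" means these compounds.

Of the compounds shown here, two have so far been measured in an assay on cell membranes for displacement of a labelled ligand from corticotropin-releasing factor receptor 1 (Rattus norvegicus); a lower number here means a stronger inhibitor, a higher number a weaker inhibitor. Compound 1 `CCCN(C)c1nc(C)nc2c(-c3c(C)cc(OC)cc3OC)c(C)nn12` gives 6.48 nM, the lower of the two numbers. Compound 2 `COc1ccc(-c2c(C)nn3c(NC4CCC4)nc(C)nc23)c(C)c1` gives 24.6 nM, and the gap between compound 2 and compound 1 lies beyond the usual scatter, so compound 1 is the stronger binder of the pair. Compound 2 differs from compound 1 in more than one place, so its number says nothing about any single change.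

Compound 3 `CCCC(C)Nc1nc(C)nc2c(-c3c(C)cc(OC)cc3OC)c(C)nn12` has not yet been measured. It differs from compound 1 in one place only: (1-methylbutyl)amino in place of methyl(propyl)amino on an aromatic carbon. Within the data shown here, no measured pair shows this change by itself, so no measured step can be quoted for it. From the numbers known, the step from compound 1 to compound 3 is expected to be small, in either direction or none beyond the scatter, a 1.3-fold lower number from compound 1 to compound 3 (0.11 log units; within the scatter). Compound 3 is therefore estimated at 5 nM, with a range from 1.5 nM to 20 nM.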

Compound 3, half-maximal inhibitory concentration: 2.14 nM
Compound 3: the middle estimate sits 2.3-fold (0.37 log units) above what was measured; the range from low to high includes it.
By their numbers in this assay, from the lowest: compound 3; then compound 1; then compound 2.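

At this position, on an aromatic carbon between two ring nitrogen atoms, the tertiary methyl(propyl)amino group can be replaced by the branched secondary (1-methylbutyl)amino group with a gain in this assay: the change gives a 3.0-fold lower number from compound 1 to compound 3 (0.48 log units; beyond the scatter). The position therefore accepts a group that carries one hydrogen-bond donor where the old group had none, and one more heavy atom, and binding improves rather than worsens. No measurement shown here explains the direction of this step.

This single change alters the donor count, the chain and the branching together, so the compounds shown cannot say which of these matters. Unbranched pentylamino and tertiary dipropylamino groups at the same position would be natural comparisons for separating these features.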